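The source may hold more compounds than are shown below. What is called first, only, known or untested is meant among the compounds shown, and "the series" means these compounds.

Measured compounds:
Compound 1 `O=C(O)CC(O)(CSCCCCCCc1cccc(Cl)c1)C(=O)O` — compound 1 gives 150000 nM
Compound 2 `O=C(O)CC(O)(CC(=O)CCCCCc1ccc(Cl)cc1Cl)C(=O)O` — compound 2 gives 25000 nM
Compound 3 `O=C(O)CC(O)(CSCCCC/C=C\c1ccc(Cl)cc1Cl)C(=O)O` — compound 3 gives 33000 nM

All three were tested in an assay on isolated protein for inhibition of ATP-citrate synthase (Rattus norvegicus); on this read-out higher numbers stand for weaker inhibition and lower numbers for stronger inhibition. Compound 1 stands at the highest number of the three: compound 3 sits at a lower number, beyond the scatter, and compound 2 sits lower still, also beyond the scatter. Compound 1 is therefore the weakest inhibitor among the measured set.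

The next compound keeps the shared core of compound 1 and changes only the aromatic group at the end of the chain. Compound 4 `O=C(O)CC(O)(CSCCCCCCc1ccc(O)cc1)C(=O)O` carries 4-hydroxyphenyl in place of 3-chlorophenyl on a saturated chain carbon, six bonds along the chain from a sulfur. For the measured compounds named here, no pair of measured compounds shows this particular change, so its effect in this assay is not known from the numbers at hand. Since compound 1 already gives 150000 nM, a weak result, the expectation is that the change will move the number little, with the step of a 1.3-fold higher number from compound 1 to compound 4 (0.12 log units; within the scatter) expected to lie within the scatter or slightly toward weaker inhibition. Compound 4 is thus estimated at 200000 nM, with a range from 60000 nM to 700000 nM.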

Compound 4, inhibition constant: 420000 nM
Compound 4: the middle estimate sits 2.1-fold (0.32 log units) below what was measured; the range from low to high includes it.
By their numbers in this assay, from the lowest: compounds 2 and 3 (each within the scatter of the next); then compound 1; then compound 4.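

In this assay, placing 4-hydroxyphenyl in place of 3-chlorophenyl on a saturated chain carbon, six bonds along the chain from a sulfur, gives a 2.8-fold higher number from compound 1 to compound 4 (0.45 log units; beyond the scatter), a modest move toward weaker inhibition. For the compounds shown here, this is the first comparison in the set that differs in one place, and it shows that the aromatic group at the end of the chain can shift the number even when inhibition is already weak. No measurement here explains the step.

This single swap removes the chlorine, adds the hydroxyl and changes the ring position all at once, so the contribution of each remains unresolved. Plain phenyl, 4-chlorophenyl or 3-hydroxyphenyl at this place would help separate these contributions, and it remains open whether a carboxylic acid on the ring would be tolerated.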